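Trifluoromethyl to difluoromethyl on the shared core: working notes

This account rests on a few compounds, and the source may have more. Where it says the series, first, only, none or still open, it means among the compounds named here.

Values so far in a physicochemical assay for acid dissociation, using potentiometric titration, at 25 degrees C, are these:

- compound 1 `COc1cnc(C(=O)Nc2ccc(F)c([C@@]3(C)N=C(N)CO[C@H]3C(F)(F)F)c2)cn1` gives 7.8
- compound 2 `COc1cnc(C(=O)Nc2ccc(F)c([C@@]3(C)N=C(N)COC3=C(F)F)c2)cn1` gives 7.9

Compound 1 stands within the scatter of compound 2, so the two values mark a single level and neither stands apart from the other. The next compound to be measured is compound 3 `COc1cnc(C(=O)Nc2ccc(F)c([C@@]3(C)N=C(N)CO[C@H]3C(F)F)c2)cn1`, and it differs from compound 1 in one place (hydrogen in place of fluoro on a saturated chain carbon bound to two fluorine atoms and a saturated ring carbon). This is hydrogen in place of fluoro on a saturated chain carbon bound to two fluorine atoms and a saturated ring carbon, which reads as trifluoromethyl to difluoromethyl.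

Among the compounds with values here, the measured pair offers no step that differs in one place, so no direct precedent exists, and the expectation rests on the structural change alone. Starting from compound 1 at 7.8, a modest upward move in this assay is expected, somewhat beyond the scatter. The expected size of the move is estimated as a number 0.50 log units higher from compound 1 to compound 3 (beyond the scatter) in this read-out. For compound 3 the estimated value is 8.3, with an expected range from 8 to 8.7 as its limits.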

Compound 3, acid dissociation constant: 8.4
The estimate for compound 3 lay 0.10 log units below the measured number; the range from low to high includes it.
By their numbers in this assay, from the lowest: compounds 1 and 2 (each within the scatter of the next); then compound 3.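

In this assay, within the data shown here, trifluoromethyl to difluoromethyl on the shared core gives a number 0.60 log units higher from compound 1 to compound 3 (beyond the scatter) and so supplies the only step that differs in one place. The earlier compounds shown here offered no such step, and this one shows that the read-out responds to a single exchange of fluoro for hydrogen on a saturated chain carbon bound to two fluorine atoms and a saturated ring carbon, by a modest amount that stands clear of the usual scatter. Nothing measured on this series speaks to the origin of the move, so the step stands as an observation only.

A single step fixes one exchange at this place on one core, so no trend across the fluorine count can yet be drawn from it. Going by these compounds, how the read-out would respond to monofluoromethyl or methyl at this place, or to an amine or a longer chain there, stays open, as does whether the same exchange would give a step of similar size on a different core.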